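A few compounds are considered here, and "the series" means these few. Any claim that something is new, unique, unknown or untested is made for them only; others in the source may bear on it.

Compound 1, with the structure `O=C(c1ccc([N+](=O)[O-])cc1)n1ccnc1-c1cccc([N+](=O)[O-])c1`, and compound 2, with the structure `O=C(c1ccc([N+](=O)[O-])cc1)n1ccnc1-c1ccccc1[N+](=O)[O-]`, share one core and differ only in where a nitro group sits on one of their aromatic rings. Both were tested in an ADME assay on HeLa cells (Homo sapiens) for cytotoxicity; a higher number here means that more compound is tolerated, a lower number that less compound is tolerated. In this assay compound 1 reaches only a limit of the assay, reported as > 100 ug/mL. In this assay compound 2 likewise reaches only a limit, reported as > 100 ug/mL. Compound 2 therefore stands where every value shown so far stands, since (the limit of > 100 ug/mL in this assay, at which 2 of the 2 values shown sit), and no number was obtained for it at all.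

Compound 3, with the structure `O=C(c1ccc([N+](=O)[O-])cc1)n1ccnc1-c1ccccc1Cl`, has not yet been tested. It differs from compound 2 in a single place: chloro in place of nitro on an aromatic carbon. Among the measured compounds shown here, with no measured step between compounds to lean on, the expectation for this assay is a step from compound 2 to compound 3 of a number no higher from compound 2 to compound 3 (the limit leaves the size open), that is, no shift beyond the ordinary scatter in either direction. On that basis compound 3 is estimated to give 100 ug/mL in this assay, within a range from 50 ug/mL to 150 ug/mL.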

Compound 3, minimum cytotoxic concentration: > 100 ug/mL
Compound 3 gave a limit, no number; the forecaster's own chance of this, stated with the estimate: 70%; the middle value sits exactly at the limit.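

No step can be read between compound 2 and compound 3, because both stop at a limit in this assay rather than giving a number: the limit of > 100 ug/mL in this assay, at which 3 of the 3 values shown sit.

The compounds shown leave open how much of any of them would harm the cells, and whether chloro in place of nitro changes that amount at all.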